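The source may hold more compounds than are shown below. What is called first, only, known or untested is meant among the compounds shown, and "the series" means these compounds.

Measured so far:

Compound 1: `O=C(NCCCOc1ccc2nc(O)ccc2c1)N(C1CCCCC1)C1CC1` — in a functional assay on the whole organism for inhibition, with Rattus norvegicus as the target, at a dose of 30 mg/kg by the oral route (a higher number here means more inhibition at the dose given (going by the name of the read-out), a lower number less inhibition), compound 1 gives 15%.
Compound 2: `O=C(NCCCOc1ccc2nc(O)ccc2c1)N(C1CCCC1)[C@H]1CCCC[C@@H]1O` — in this assay compound 2 gives 20%.

Both numbers are small and lie within the scatter of each other, so the two compounds cannot be told apart on these data; compound 2 simply stands with the other measured compound at a low level of inhibition. Going by the values given here, no pair among the measured compounds differs in a single place, so no step has been quantified.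

Compound 3, `O=C(NCCCOc1ccc2nc(O)ccc2c1)N(C1CCCCC1)[C@H]1CCCC[C@@H]1O`, remains to be measured in this assay. It differs from compound 2 as follows:

cyclohexyl in place of cyclopentyl on an amide-type nitrogen

With both measured compounds giving low numbers, and with compound 1 already carrying a cyclohexyl on the same amide-type nitrogen without a visible difference from compound 2, nothing in the data points to a shift in either direction. The step from compound 2 to compound 3 is expected to be none beyond the scatter, no change at the digits printed from compound 2 to compound 3 (within the scatter). Compound 3 is therefore estimated to give 20% in this assay, with a range from 5% to 35%.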

Compound 3, a percentage reported as inhibition, in the whole organism at one dose (the size of the read-out at that dose, not a potency): 18%
The estimate for compound 3 lay 2 percentage points above the measured number; low and high end bracket the measured number.
By their numbers in this assay, from the lowest: compounds 1, 3 and 2 (each within the scatter of the next).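

In this assay, cyclohexyl in place of cyclopentyl on the amide-type nitrogen gives a number 2 percentage points lower from compound 2 to compound 3 (within the scatter), which puts a first measured size on a single exchange at this position and shows that this one-carbon difference in ring size does not separate compound 2 from compound 3 at this dose. On the same nitrogen, 2-hydroxycyclohexyl in place of cyclopropyl gives a number 3 percentage points higher from compound 1 to compound 3 (within the scatter), so even this exchange of a different ring and a hydroxyl-bearing substituent leaves compound 1 and compound 3 indistinguishable, and all the exchanges read so far on this nitrogen stay inside the usual scatter at a low level of inhibition. No accompanying measurement bears on these results, so the data offer no explanation for them.

All the compounds shown carry saturated carbon rings on this nitrogen, so it remains open whether an open-chain group such as a longer alkyl chain, or a ring bearing an amine or a carboxylic acid, would give a number beyond the scatter of these. With a single oral dose in the whole organism, the data also leave open how these compounds would compare at other doses.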